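A few compounds are considered here, and "the series" means these few. Any claim that something is new, unique, unknown or untested is made for them only; others in the source may bear on it.

Measured compounds:
compound 1 `CN(c1nc2ccc(NC(=O)CCc3ccc(C(F)(F)F)cc3)cc2[nH]1)C1CC1` — "not determined" (no result reported)
compound 2 `CC(C)N(C)c1nc2ccc(NC(=O)CCc3ccc(C(F)(F)F)cc3)cc2[nH]1` — 21 nM
compound 3 `CN(C)c1nc2ccc(NC(=O)CCc3ccc(C(F)(F)F)cc3)cc2[nH]1` — "not determined" (no result reported)

In a functional assay on CHO-K1 cells for antagonist activity at melanin-concentrating hormone receptor 1 (Homo sapiens), read by FLIPR and calcium flux (a higher number here means a weaker inhibitor, a lower number a stronger inhibitor), only compound 2 carries a number, 21 nM. Compound 1 and compound 3 have no result in this assay, so compound 3 cannot be placed against compound 2 on the numbers shown, and no step between measured compounds exists to anchor the change that follows.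

Compound 4 `CN(c1nc2ccc(NC(=O)CCc3ccc(C(F)(F)F)cc3)cc2[nH]1)C1CCCC1` differs from compound 3 by cyclopentyl in place of methyl on a nitrogen on an aromatic ring. Within the data shown here, with no number for compound 3, the size and direction of the step in this assay cannot be stated; the only reference is compound 2, which also bears a branched group on that nitrogen. Compound 4 is therefore expected to land near that reading, estimated at 30 nM with a range of 8 nM to 120 nM, and this estimate rests on one measured point only.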

Compound 4, half-maximal inhibitory concentration: 22 nM
Beside the measured number, compound 4's estimate is 1.4-fold (0.13 log units) above it; the range from low to high includes it.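

In this assay, putting a cyclopentyl group on the nitrogen that carried isopropyl gives a 1.0-fold higher number from compound 2 to compound 4 (0.02 log units; within the scatter), so this position now has its first readable step. Within the scatter, the ring-bearing cyclopentyl and the open-chain isopropyl cannot be told apart at this nitrogen. No measured evidence bears on this result.

Going by these compounds, compound 1 and compound 3 have no number, so steps to them cannot be read, and the effect of the smaller methyl remains unknown. On these data alone, whether a piperidine ring, a longer chain or a carboxylic acid at this nitrogen would keep the reading stays open.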